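The source may hold more compounds than are shown below. What is called first, only, known or untested is meant among the compounds shown, and "the series" means these compounds.

Measured so far in a functional assay on HCT-116 cells (Homo sapiens) for inhibition, read by sulforhodamine B assay, with a stated time of 3 days; on this read-out higher numbers stand for weaker inhibition and lower numbers for stronger inhibition:
compound 1 `O=C1Nc2ccc(F)cc2/C1=C\C(=O)c1ccc(O)cc1F` at 1070 nM
compound 2 `O=C1Nc2ccc(F)cc2/C1=C\C(=O)c1cnc2ccc(Cl)nn12` at 1410 nM
compound 3 `COc1ccc(C(=O)Nc2ccc3c(c2)/C(=C/Nc2cccc(N4CCN(C)CC4)c2)C(=O)N3)cc1` at 2010 nM

Compound 3 stands within the scatter of both compound 1 and compound 2, so these three values give no order. Compound 4 `CN1CCC(C(=O)Nc2ccc3c(c2)/C(=C/Nc2cccc(N4CCN(C)CC4)c2)C(=O)N3)CC1` keeps the rest of compound 3 and changes one group (1-methylpiperidin-4-yl in place of 4-methoxyphenyl on a carbonyl carbon), with 1-methylpiperidin-4-yl in place of 4-methoxyphenyl on a carbonyl carbon. Going by the values given here, no pair of measured compounds differs in one place, so the data do not size this change or any other single change in this assay. Among the compounds with values here, the only anchors are compound 3 at 2010 nM and the close values of two compounds with different structures. No step beyond the scatter is expected, in either direction, though the uncertainty is wide. The estimate amounts to a 1.1-fold lower number from compound 3 to compound 4 (0.02 log units; within the scatter) in the expected case. For compound 4 the estimate is 1900 nM with 500 nM to 7000 nM as its expected range.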

Compound 4, half-maximal inhibitory concentration: 4670 nM
Estimate against measurement, compound 4: 2.5-fold (0.39 log units) below; low and high end bracket the measured number.
By their numbers in this assay, from the lowest: compounds 1, 2 and 3 (each within the scatter of the next); then compound 4.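

Going by these compounds alone, this is the first comparison that differs in one place: in this assay, 1-methylpiperidin-4-yl in place of 4-methoxyphenyl on a carbonyl carbon gives a 2.3-fold higher number from compound 3 to compound 4 (0.37 log units; beyond the scatter), a modest step beyond the scatter. The group on this carbonyl carbon therefore affects the number with the rest of the structure held constant, and here 4-methoxyphenyl goes with the stronger inhibition. Nothing available explains the step.

The change replaces a six-membered aromatic ring of carbon only and its oxygen-bearing group with a non-aromatic ring holding a nitrogen, so the compounds shown do not separate these differences. From the compounds shown here alone, how an unsubstituted phenyl or a piperidin-4-yl without its methyl group would compare on this carbonyl carbon remains open.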